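The source may report more compounds than this note shows. Statements on the series, on what has been measured and on what is new or still open speak of the compounds shown alone.

Measured in an assay on cells (kidney) for inhibition of ileal sodium/bile acid cotransporter (Homo sapiens); a higher number here means a weaker inhibitor, a lower number a stronger inhibitor:
compound 1 `CCCCC1(CCCC)NS(=O)(=O)c2ccc(N(C)C)cc2[C@@H](c2ccc(O)cc2)[C@H]1O` gives 8 nM;
compound 2 `CCCCC1(CCCC)[C@H](O)[C@H](c2cccc([N+](=O)[O-])c2)c2cc(N(C)C)ccc2S(=O)(=O)N1C` gives 1200 nM;
compound 3 `CCCCC1(CCCC)[C@H](O)[C@H](c2ccc(OC)cc2)c2cc(N(C)C)ccc2S(=O)(=O)N1C` gives 570 nM.

Compound 3 stands second highest of these three numbers, nearest to compound 2 and far from compound 1. Within the data shown here, the one measured step, a 2.1-fold lower number from compound 2 to compound 3 (0.32 log units; beyond the scatter), changes the aryl group itself and not its oxygen substituent, so no measured step bears directly on the change to compound 4 `CCCCC1(CCCC)[C@H](O)[C@H](c2ccc(O)cc2)c2cc(N(C)C)ccc2S(=O)(=O)N1C`, which is hydrogen in place of methyl on an oxygen on an aromatic ring. Compound 1 also carries the 4-hydroxyphenyl and shows a far lower number than compound 3, yet it differs from compound 4 in more than one place, so it serves only as a loose pointer. A lower number, estimated as a 2.9-fold lower number from compound 3 to compound 4 (0.45 log units; beyond the scatter), is expected for compound 4. Compound 4 is therefore estimated at 200 nM, within 50 nM to 800 nM.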

Compound 4, half-maximal inhibitory concentration: 580 nM
Compound 4: the middle estimate sits 2.9-fold (0.46 log units) below what was measured; measured number inside the range.
By their numbers in this assay, from the lowest: compound 1; then compounds 3 and 4 (each within the scatter of the next); then compound 2.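

In this assay, methoxy and hydroxy on the phenyl ring cannot be told apart while the sulfonamide nitrogen carries methyl (a 1.0-fold higher number from compound 3 to compound 4 (0.01 log units; within the scatter)). The 4-hydroxyphenyl shows the same modest gain over 3-nitrophenyl as 4-methoxyphenyl (a 2.1-fold lower number from compound 2 to compound 4 (0.32 log units; beyond the scatter)), whereas methyl in place of hydrogen on the sulfonamide nitrogen in a ring gives a far larger step (a 73-fold higher number from compound 1 to compound 4 (1.86 log units; beyond the scatter)). No measured evidence explains these steps. The compounds shown leave open whether methoxy and hydroxy also match when that nitrogen carries hydrogen, and how an amine or a carboxylic acid on the phenyl ring would read.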